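A few compounds are considered here, and "the series" means these few. Any claim that something is new, unique, unknown or untested is made for them only; others in the source may bear on it.

For the measured compounds named here, in a functional assay on A2780 cells (Homo sapiens) for antiproliferative activity, read by MTT assay, with a stated time of 72 h (a lower number here means a stronger inhibitor, a higher number a weaker inhibitor), three compounds sharing one core have numbers so far. Compound 1 `Cc1ccc(C2CC(c3ccccc3)=NN2C(=O)c2cc3ccccc3o2)cc1` gives 16.6 ug/mL and compound 2 `O=C(c1cc2ccccc2o1)N1N=C(c2ccccc2)CC1c1ccc(Cl)cc1` gives 5.13 ug/mL. Chloro in place of methyl on an aromatic carbon accounts for a 3.2-fold lower number from compound 1 to compound 2 (0.51 log units; beyond the scatter), a modest step beyond the scatter. With chloro in place of hydrogen on an aromatic carbon of compound 2, compound 3 `O=C(c1cc2ccccc2o1)N1N=C(c2ccc(Cl)cc2)CC1c1ccc(Cl)cc1` gives 8.5 ug/mL. That change amounts to a 1.7-fold higher number from compound 2 to compound 3 (0.22 log units; within the scatter), which is within the scatter, and compound 3 stands within the scatter of both other compounds.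

Compound 4 `O=C(c1cc2ccccc2o1)N1N=C(c2ccc(Cl)cc2)CC1c1ccccc1Cl` has the same atoms as compound 3, joined differently: 2-chlorophenyl in place of 4-chlorophenyl on a saturated ring carbon. Its 2-chlorophenyl takes the place of the 4-chlorophenyl on the saturated ring carbon. Neither measured step shows such a change. The step of a 3.2-fold lower number from compound 1 to compound 2 (0.51 log units; beyond the scatter) altered a substituent on the group at this same carbon, so it suggests that this group can matter, but it gives no direction for the present change. The step of a 1.7-fold higher number from compound 2 to compound 3 (0.22 log units; within the scatter) was made elsewhere. No step beyond the scatter is therefore expected in this assay, and neither direction is favoured. The expected change is a 1.1-fold lower number from compound 3 to compound 4 (0.03 log units; within the scatter). For compound 4 the estimated value is 8 ug/mL, with an expected range from 3.5 ug/mL to 18 ug/mL.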

Compound 4, half-maximal inhibitory concentration: 44.8 ug/mL
Compound 4: middle estimate off by 5.6-fold (0.75 log units), on the low side; the whole stated range lies below it.
By their numbers in this assay, from the lowest: compounds 2, 3 and 1 (each within the scatter of the next, the first and the last beyond it); then compound 4.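

In this assay the exchange of 4-chlorophenyl for 2-chlorophenyl on the saturated ring carbon gives a 5.3-fold higher number from compound 3 to compound 4 (0.72 log units; beyond the scatter), a modest step beyond the scatter and towards a weaker inhibitor. The earlier step at this carbon replaced one substituent on the phenyl group with another, whereas here the atoms stay the same and only their joining differs, so the way the chlorine is attached to this phenyl group is enough on its own to shift the number. The data hold no measurement that would explain this shift.

The compounds shown leave open whether this higher number belongs to the chlorine of 2-chlorophenyl in particular, or whether a methyl group, a methoxy group or a fluorine in the place of that chlorine would give a similar result. For the compounds shown here, they also leave open whether the step would keep its size and direction without the other chlorine, which compound 3 and compound 4 share, since this pair is the only comparison of its kind here.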